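Swapping the sulfur-bearing side chain for benzylcarbamoyl

A few compounds are considered here, and "the series" means these few. Any claim that something is new, unique, unknown or untested is made for them only; others in the source may bear on it.

Compound 3 `CC(C)/N=C(\S)OC[C@H]1OC(n2cnc3c(NC4CCOC4)ncnc32)[C@H](O)[C@@H]1O` gives 36 nM in an assay on DDT1 cells (Cricetulus griseus) for binding affinity to adenosine receptor A1 (Homo sapiens), read by radioligand binding (a lower number here means a stronger inhibitor, a higher number a weaker inhibitor), the lowest of the three numbers recorded. Compound 1 `CC/N=C(\S)OC[C@H]1OC(n2cnc3c(NC4CCOC4)nc(Cl)nc32)[C@H](O)[C@@H]1O` stands nearest with 55 nM, within the scatter of compound 3, while compound 2 `CCCNC(=O)OC[C@H]1OC(n2cnc3c(NC4CCOC4)ncnc32)[C@H](O)[C@@H]1O` lies furthest with 235 nM. Compound 4 `O=C(NCc1ccccc1)OC[C@H]1OC(n2cnc3c(NC4CCOC4)ncnc32)[C@H](O)[C@@H]1O` differs from compound 3 by a group of 10 heavy atoms (8 carbon, 1 nitrogen, 1 oxygen; one six-membered aromatic ring of carbon only) in place of a group of 6 heavy atoms (4 carbon, 1 nitrogen, 1 sulfur; no ring), on an oxygen on a saturated carbon. Going by the values given here, the one measured step that bears on this exchange is a 6.5-fold lower number from compound 2 to compound 3 (0.81 log units; beyond the scatter), and compound 2, like compound 4, carries an oxygen where compound 3 carries sulfur. Reversing that exchange is therefore expected to raise the number, though the benzyl chain that enters has no measured counterpart among these compounds. Compound 4 is expected at 200 nM, a step of a 5.6-fold higher number from compound 3 to compound 4 (0.74 log units; beyond the scatter), with a range from 60 nM to 650 nM.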

Compound 4, inhibition constant: 1830 nM
Estimate against measurement, compound 4: 9.2-fold (0.96 log units) below, and the stated range ends below it.
By their numbers in this assay, from the lowest: compounds 3 and 1 (each within the scatter of the next); then compound 2; then compound 4.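

In this assay, phenyl in place of ethyl on the saturated chain carbon bound to an amide-type nitrogen gives a 7.8-fold higher number from compound 2 to compound 4 (0.89 log units; beyond the scatter) with the carbonyl kept, so the far end of this chain also matters, not only the exchange of sulfur for oxygen. The whole exchange for benzylcarbamoyl amounts to a 51-fold higher number from compound 3 to compound 4 (1.71 log units; beyond the scatter) on the same oxygen on a saturated carbon. Nothing available explains why the number rises. Still open, from the compounds shown here alone, is how a benzyl group behaves with the sulfur kept. Also open, going by these compounds, is whether a longer chain or a cyclohexyl ring in place of phenyl gives a similar rise.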